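The source may report more compounds than this note shows. Statements on the series, on what has been measured and on what is new or still open speak of the compounds shown alone.

Compound 3 `COc1ccc(C(=O)n2c(C(C)C)nc3ccccc32)cc1` gives 630 nM in a functional assay on HL-60 cells (Homo sapiens) for cytotoxicity, read by MTT assay, with a stated time of 72 h (a lower number here means a stronger inhibitor, a higher number a weaker inhibitor), and holds the highest number of the three measured compounds, beyond the scatter from both of the others. Compound 1 `COc1ccc(-c2nc3ccccc3n2C(=O)c2cccc3ccccc23)cc1` gives 146 nM and compound 2 `O=C(c1cccc2ccccc12)n1c(C2CCC2)nc2ccccc21` gives 180 nM in this assay as well. Compound 4 `COc1ccc(C(=O)n2c(-c3ccc(OC)cc3)nc3ccccc32)cc1` has 4-methoxyphenyl in place of isopropyl on an aromatic carbon and is otherwise the same as compound 3. Within the data shown here, the only measured step at this place (a 1.2-fold higher number from compound 1 to compound 2 (0.09 log units; within the scatter)) has cyclobutyl in place of 4-methoxyphenyl and stays within the scatter. That step runs in the opposite direction, involves a different alkyl group and sits on a different remainder of the molecule, so it is only a loose guide. Going by these compounds, on this single small step, no change beyond the scatter is expected in this assay and the direction stays open, with a slight lean to a lower number. The estimated change is a 1.3-fold lower number from compound 3 to compound 4 (0.12 log units; within the scatter) and lies within the scatter. In this assay compound 4 is estimated at 480 nM with a range from 130 nM to 1600 nM expected.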

Compound 4, half-maximal inhibitory concentration: 175 nM
Compound 4: middle estimate off by 2.7-fold (0.44 log units), on the high side; low and high end bracket the measured number.
By their numbers in this assay, from the lowest: compounds 1, 4 and 2 (each within the scatter of the next); then compound 3.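

In this assay, among these compounds, the swap of isopropyl for 4-methoxyphenyl, on the aromatic carbon between two ring nitrogen atoms, gives a 3.6-fold lower number from compound 3 to compound 4 (0.56 log units; beyond the scatter) and is the first step at this place to go beyond the scatter. The earlier step, a 1.2-fold higher number from compound 1 to compound 2 (0.09 log units; within the scatter) with cyclobutyl in place of 4-methoxyphenyl, stayed within it, so the group at this place can move the number on one remainder of the molecule and not on another, although the two steps also differ in the alkyl group involved. No measurement on hand accounts for this difference.

Going by these compounds, whether isopropyl on the remainder of compound 2, or cyclobutyl on the remainder of compound 3, would follow the same trend stays open. So does the reading for an amine or a longer alkyl chain at this place.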